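A few compounds are considered here, and "the series" means these few. Any claim that something is new, unique, unknown or untested is made for them only; others in the source may bear on it.

Compound 1 `O=C1c2c[n+]([O-])c3ccccc3c2C(=O)c2c1c1ccccc1n2Cc1cn(CC(O)CO)nn1` gives 250 nM in a functional assay on HCT-116 cells (Homo sapiens) for cytotoxicity, read by MTT assay, with a stated time of 72 h; a lower number here means a stronger inhibitor, a higher number a weaker inhibitor.
Compound 2 `CC1(C)OC[C@H](Cn2cc(Cn3c4c(c5ccccc53)C(=O)c3c[n+]([O-])c5ccccc5c3C4=O)nn2)O1` gives 130 nM in this assay.
Compound 3 `O=C1c2c[n+]([O-])c3ccccc3c2C(=O)c2c1c1ccccc1n2Cc1cn([C@H]2C[C@H](O)[C@@H](CO)O2)nn1` gives 120 nM in this assay.

Compound 1 has the highest of the three numbers: its nearest neighbour is compound 2, with a 1.9-fold lower number from compound 1 to compound 2 (0.28 log units; within the scatter), and its furthest is compound 3, with a 2.1-fold lower number from compound 1 to compound 3 (0.32 log units; beyond the scatter); between the other two there is a 1.1-fold lower number from compound 2 to compound 3 (0.03 log units; within the scatter). Compound 4 `CN1CCN(CCCCCCn2c3c(c4ccccc42)C(=O)c2c[n+]([O-])c4ccccc4c2C3=O)CC1` differs from compound 1 by 5-(4-methylpiperazin-1-yl)pentyl in place of 1-(2,3-dihydroxypropyl)-1H-1,2,3-triazol-4-yl on a saturated chain carbon bound to an aromatic nitrogen. Within the data shown here, none of the measured steps touches this part of the molecule; all keep the triazole and vary only what hangs on it, and none moves far. Among the measured compounds shown here, with no step to lean on and a large change, compound 4 is expected near compound 1, with a 1.7-fold lower number from compound 1 to compound 4 (0.22 log units; within the scatter), estimated at 150 nM (range 40 nM to 600 nM).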

Compound 4, half-maximal inhibitory concentration: 2900 nM
Beside the measured number, compound 4's estimate is 19-fold (1.29 log units) below it; measured number above the stated range.
By their numbers in this assay, from the lowest: compounds 3, 2 and 1 (each within the scatter of the next, the first and the last beyond it); then compound 4.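

Replacing the whole 1-(2,3-dihydroxypropyl)-1H-1,2,3-triazol-4-yl with 5-(4-methylpiperazin-1-yl)pentyl on a saturated chain carbon bound to an aromatic nitrogen gives a 12-fold higher number from compound 1 to compound 4 (1.06 log units; beyond the scatter) in this assay. The position therefore responds strongly to this exchange, whereas the earlier changes, all of which kept the triazole, moved the number far less. Nothing available here accounts for the size of this step.

This one step changes the triazole and the terminal group together, leaving their separate contributions unresolved. On these data alone, whether a triazole carrying 4-methylpiperazin-1-yl, or a pentyl chain ending in morpholine or a carboxylic acid, would stay near compound 1 remains open.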